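Toward compound 4: a nitrofuran hydrazone with an isopropyl arm

The source may report more compounds than this note shows. Statements on the series, on what has been measured and on what is new or still open speak of the compounds shown alone.

Compound 1 `O=C(N/N=C/c1ccc([N+](=O)[O-])o1)c1ccccc1Oc1ccccc1` was tested in an ADME assay on LL24 cells (Homo sapiens) for inhibition, read by MTT assay, with a stated time of 24 h; on this read-out higher numbers stand for weaker inhibition and lower numbers for stronger inhibition; in this assay compound 1 gives > 200000 nM, a limit of the assay rather than a number.
Compound 2 `CCCCc1ccc(C(=O)N/N=C/c2ccc([N+](=O)[O-])o2)cc1` in this assay gives > 200000 nM, again a limit.
Compound 3 `N#Cc1ccc(C(=O)N/N=C/c2ccc([N+](=O)[O-])o2)cc1` in this assay gives > 200000 nM, also a limit.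

All three measured compounds share one core and differ only in the group attached to the benzene ring of the benzoyl part. For the measured compounds named here, compound 3 stands at the limit of the assay, as does every other value shown here, so no compound can be ranked against another. Going by the values given here, the one comparison between neighbours, a step that the two limits leave unreadable from compound 2 to compound 3, cannot be read because the limit of > 200000 nM in this assay, at which 3 of the 3 values shown sit, is where both values sit.

Compound 4 `CC(C)c1ccc(C(=O)N/N=C/c2ccc([N+](=O)[O-])o2)cc1` differs from compound 3 by isopropyl in place of cyano on an aromatic carbon. The isopropyl that enters is a small hydrocarbon chain, closer in kind to the butyl of compound 2 than to the cyano it replaces. Since compound 2 with its butyl sits at the same limit as compound 3, nothing here points toward a measurable inhibition for compound 4; the expected step that the limit leaves unreadable from compound 3 to compound 4 is none beyond the scatter. Compound 4 is therefore estimated at 300000 nM, with a range from 100000 nM to 1000000 nM, and most likely the assay will again return only a limit.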

Compound 4, half-maximal inhibitory concentration: > 200000 nM
Compound 4 gave a limit, no number (the forecaster's own chance of this, stated with the estimate: 85%); the middle value lies beyond the limit too.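

Compound 4 adds no readable step against compound 2 or compound 3, because all of these compounds sit at the same limit, which is not a number: the limit of > 200000 nM in this assay, at which 4 of the 4 values shown sit. The compounds shown leave open how strongly any of them inhibits in this assay and whether any other group on the benzene ring would give a readable number.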